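Chloro to fluoro on the aryl ring of compound 3

This account rests on a few compounds, and the source may have more. Where it says the series, first, only, none or still open, it means among the compounds named here.

Three compounds share one core and differ only in the aryl group on the carbonyl carbon: compound 1 `Cc1ccc(C(=O)NC(=S)NNc2ncnc3ccccc23)cc1`, compound 2 `COc1ccccc1C(=O)NC(=S)NNc1ncnc2ccccc12` and compound 3 `O=C(NC(=S)NNc1ncnc2ccccc12)c1ccccc1Cl`. In a functional assay on MGC-803 cells (Homo sapiens) for cytotoxicity, read by MTT assay, with a stated time of 72 h (a lower number here means a stronger inhibitor, a higher number a weaker inhibitor), compound 1 gives 3760 nM, compound 2 gives 14300 nM and compound 3 gives 9140 nM. Compound 3 thus stands second highest of the three, close to compound 2 and further from compound 1: a 2.4-fold higher number from compound 1 to compound 3 (0.39 log units; beyond the scatter), while a 1.6-fold lower number from compound 2 to compound 3 (0.19 log units; within the scatter). Compound 4 `O=C(NC(=S)NNc1ncnc2ccccc12)c1ccccc1F` carries fluoro in place of chloro on an aromatic carbon. For the measured compounds named here, no measured pair exchanges one halogen for another; the only step at this aromatic carbon, a 1.6-fold lower number from compound 2 to compound 3 (0.19 log units; within the scatter), is small, and a 3.8-fold higher number from compound 1 to compound 2 (0.58 log units; beyond the scatter) is modest. The expectation is therefore a 1.0-fold higher number from compound 3 to compound 4 (0.02 log units; within the scatter), nothing beyond the scatter. Compound 4 is estimated at 9500 nM, between 4500 nM and 20000 nM.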

Compound 4, half-maximal inhibitory concentration: 5010 nM
Beside the measured number, compound 4's estimate is 1.9-fold (0.28 log units) above it, and the stated range covers the measured number.
By their numbers in this assay, from the lowest: compounds 1, 4, 3 and 2 (each within the scatter of the next, the first and the last beyond it).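

In this assay, the exchange of one halogen for another on this aromatic carbon stays within the scatter (a 1.8-fold lower number from compound 3 to compound 4 (0.26 log units; within the scatter)), so chloro and fluoro are not told apart here. Fluoro in place of methoxy goes beyond the scatter (a 2.9-fold lower number from compound 2 to compound 4 (0.46 log units; beyond the scatter)), whereas 2-fluorophenyl in place of 4-methylphenyl does not (a 1.3-fold higher number from compound 1 to compound 4 (0.12 log units; within the scatter)), so those two aryl groups are not told apart either. Nothing available explains these steps. The compounds shown leave open how an amine or a carboxylic acid would read on this aromatic carbon.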